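Notes on replacing the chain of compound 2

The source may report more compounds than this note shows. Statements on the series, on what has been measured and on what is new or still open speak of the compounds shown alone.

Measured in a functional assay on HepG2 cells (Homo sapiens) for inhibition, read by MTT assay, with a stated time of 72 h; a lower number here means a stronger inhibitor, a higher number a weaker inhibitor:
- compound 1 `CC(C)CCN(CCCCCCC(=O)NO)c1ncc(C(=O)NCc2cccnc2)s1`: 7000 nM
- compound 2 `O=C(CCCCCCCN(Cc1ccc(F)cc1)c1ncc(C(=O)NCCCn2ccnc2)s1)NO`: 26000 nM

Compound 2 holds the higher of the two numbers in this assay, with a gap to compound 1 that lies beyond the scatter. The two compounds differ in more than one place, so that gap isolates no single change.

Compound 3 `O=C(NO)c1ccc(CN(Cc2ccc(F)cc2)c2ncc(C(=O)NCCCn3ccnc3)s2)cc1` carries 4-(hydroxycarbamoyl)phenyl in place of 6-(hydroxycarbamoyl)hexyl on a saturated chain carbon bound to a nitrogen on an aromatic ring. Among the compounds with values here, no measured pair shows this change, so the expectation starts from compound 2 at 26000 nM and stays cautious. The expected result is a 1.7-fold lower number from compound 2 to compound 3 (0.24 log units; within the scatter), a small move towards a lower number that stays within the scatter. For compound 3 the estimate is 15000 nM, with an expected range of 4000 nM to 50000 nM.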

Compound 3, half-maximal inhibitory concentration: 79000 nM
Estimate against measurement, compound 3: 5.3-fold (0.72 log units) below; the whole stated range lies below it.
By their numbers in this assay, from the lowest: compound 1; then compound 2; then compound 3.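

In this assay, within the data shown here, 4-(hydroxycarbamoyl)phenyl in place of 6-(hydroxycarbamoyl)hexyl on a saturated chain carbon bound to a nitrogen on an aromatic ring gives a 3.0-fold higher number from compound 2 to compound 3 (0.48 log units; beyond the scatter) and so gives weaker inhibition, the first reading of this position on its own. The two groups match in heavy atoms, hydrogen-bond donors and hydrogen-bond acceptors, and the counted difference is the six-membered aromatic ring of carbon only, so this position responds to a change that leaves those counts untouched. No supporting data bear on why the number rises.

As far as these compounds go, the change is read on the background of compound 2 only, and whether it runs the same way with the other substituents of compound 1 stays open. Also open, from the compounds shown here alone, is how a shorter chain, a longer chain or a carboxylic acid in place of the hydroxycarbamoyl group would read at this position.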